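The source may report more compounds than this note shows. Statements on the series, on what has been measured and on what is new or still open speak of the compounds shown alone.

Compound 1 `Cc1c(C(=O)N/N=C\c2ccccc2C(F)(F)F)oc2cccc(O)c12` — 26200 nM
Compound 2 `Cc1ccc(O)c(/C=N\NC(=O)c2oc3cccc(O)c3c2C)c1` — 7350 nM
Compound 3 `COc1cccc(/C=N\NC(=O)c2oc3cccc(O)c3c2C)c1` — a limit, >= 40000 nM

Of the compounds shown here, three sharing one core have been tested in a functional assay on PC-3 cells (Homo sapiens) for inhibition; a higher number here means a weaker inhibitor, a lower number a stronger inhibitor. Compound 1 gives 26200 nM. Compound 2 gives 7350 nM, the lowest of the two numbers; compound 1 is the nearest and stands beyond the scatter above it. For compound 3 the assay reports only a limit, >= 40000 nM, which is the limit of >= 40000 nM in this assay, at which 1 of the 3 values shown sits.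

Compound 4 `Cc1c(C(=O)N/N=C\c2cc(Cl)ccc2O)oc2cccc(O)c12` differs from compound 2 in one place: chloro in place of methyl on an aromatic carbon. Going by the values given here, only one measured step bears on this change, and loosely: an at least 5.4-fold higher number from compound 2 to compound 3 (0.73 log units; beyond the scatter), in which the whole substitution pattern of the ring is exchanged and the hydroxy group is lost. The change to compound 4 keeps the hydroxy group and trades one heavy atom for another of similar bulk, para to a hydroxy group. Nothing measured here separates methyl from chloro at that position.

For compound 4 the expected step is a 1.1-fold lower number from compound 2 to compound 4 (0.05 log units; within the scatter), not beyond the scatter. The estimate for compound 4 in this assay is 6500 nM, within the range from 2500 nM to 17000 nM.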

Compound 4, half-maximal inhibitory concentration: 3120 nM
Compound 4: the middle estimate sits 2.1-fold (0.32 log units) above what was measured, and the stated range covers the measured number.
By their numbers in this assay, from the lowest: compound 4; then compound 2; then compound 1. At a limit, above all of these: compound 3.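

In this assay, going by these compounds alone, the step for chloro in place of methyl, para to a hydroxy group, is a 2.4-fold lower number from compound 2 to compound 4 (0.37 log units; beyond the scatter) and is the only measured change confined to this single position; the earlier compounds could show only what happened when the whole ring pattern was exchanged. With the hydroxy group and the rest of the molecule unchanged, this one-atom exchange therefore moves the number beyond the scatter, though only modestly. Against the 3-methoxyphenyl group of compound 3, the 5-chloro-2-hydroxyphenyl group gives an at least 12-fold lower number from compound 3 to compound 4 (1.10 log units; beyond the scatter) and that step is large, but the value of compound 3 is a limit, so the step is read as one: the limit of >= 40000 nM in this assay, at which 1 of the 4 values shown sits.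

The compounds shown leave open whether bromo, fluoro, trifluoromethyl or a nitrile at this place, para to the hydroxy group, would lower the number further, and whether chloro would bring the same step in a ring carrying a methoxy group instead of that hydroxy group. They also leave open what an amine or a methoxy group would do in place of the hydroxy group on the shared core, which all four compounds keep.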